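From 3,4-dimethylphenyl back to a halogenated phenyl

A few compounds are considered here, and "the series" means these few. Any claim that something is new, unique, unknown or untested is made for them only; others in the source may bear on it.

Measured so far in a functional assay on HeLa cells (Homo sapiens) for inhibition, read by CCK-8 assay, with a stated time of 48 h; on this read-out higher numbers stand for weaker inhibition and lower numbers for stronger inhibition:
compound 1 `O=C1CSC(N2N=C(c3ccc(Br)cc3)CC2c2ccc3ccccc3c2)=N1`: 4220 nM
compound 2 `Cc1ccc(C2=NN(C3=NC(=O)CS3)C(c3ccc4ccccc4c3)C2)cc1C`: 860 nM

Compound 2 holds the lower of the two numbers in this assay, which makes it the stronger inhibitor of this pair. The next compound to be measured is compound 3 `O=C1CSC(N2N=C(c3ccc(Cl)cc3)CC2c2ccc3ccccc3c2)=N1`, in which 4-chlorophenyl takes the place of 3,4-dimethylphenyl: 4-chlorophenyl in place of 3,4-dimethylphenyl on a carbon with a double bond to nitrogen. The change falls on a carbon with a double bond to nitrogen, the same place where compound 1 and compound 2 differ. Among the compounds with values here, one measured step bears on it: a 4.9-fold lower number from compound 1 to compound 2 (0.69 log units; beyond the scatter), modest but beyond the scatter, with 3,4-dimethylphenyl in place of 4-bromophenyl. Within the data shown here, compound 3 does not return to the 4-bromophenyl of compound 1, and no compound with 4-chlorophenyl has been measured, so the comparison is indirect. Even so, most of that step is expected to reverse, moving the number up toward compound 1 at 4220 nM. The estimated step is a 3.7-fold higher number from compound 2 to compound 3 (0.57 log units; beyond the scatter). For compound 3 the expected value is 3200 nM, with an estimated range from 1400 nM to 7000 nM.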

Compound 3, half-maximal inhibitory concentration: 6320 nM
For compound 3 the middle estimate is 2.0-fold (0.30 log units) below the measured one, within the range that was stated.
By their numbers in this assay, from the lowest: compound 2; then compounds 1 and 3 (each within the scatter of the next).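

In this assay the step of a 7.3-fold higher number from compound 2 to compound 3 (0.87 log units; beyond the scatter) shows that the higher number seen with 4-bromophenyl is not confined to bromo, since 4-chlorophenyl on the same carbon with a double bond to nitrogen also stands well apart from 3,4-dimethylphenyl. The direct exchange of the two halogens gives a 1.5-fold higher number from compound 1 to compound 3 (0.18 log units; within the scatter) and lies within the scatter, so this assay does not separate chloro from bromo on this aromatic carbon. Across these three compounds, the clear difference lies between 3,4-dimethylphenyl and the two 4-halophenyl groups, while the halogen exchange itself makes no clear difference, and nothing at hand explains that difference.

From the compounds shown here alone, it remains open whether both methyl groups of compound 2 are needed, which a single methyl group on the phenyl ring would help to settle. Also unresolved is how this position would respond to a methoxy group, an amine or a carboxylic acid on the phenyl ring, or to a different halogen such as fluoro.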